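Pyridyl for phenyl on the side arm of compound 1

The source may report more compounds than this note shows. Statements on the series, on what has been measured and on what is new or still open speak of the compounds shown alone.

Among the compounds with values here, compound 1 `CCc1cc(Nc2nc(N[C@@H](C)c3ccc(F)cc3)nc3cccc(F)c23)n[nH]1` gives 41 nM in an assay on isolated protein for inhibition of G protein-coupled receptor kinase 6 (Homo sapiens), read by scintillation counting, radiometric assay and 33P incorporation, with a stated time of 80 min, in the presence of a further agent that is not named here (a lower number here means a stronger inhibitor, a higher number a weaker inhibitor), the lowest of the three numbers measured so far. Compound 3 `CCc1cc(Nc2nc(N[C@@H](C)c3ccc(F)cc3)nc3ccccc23)n[nH]1` gives 120 nM and compound 2 `CCc1cc(Nc2nc(NCc3ccc(F)cc3)nc3ccccc23)n[nH]1` gives 250 nM. The step of a 2.9-fold higher number from compound 1 to compound 3 (0.47 log units; beyond the scatter) and the step of a 2.1-fold lower number from compound 2 to compound 3 (0.32 log units; beyond the scatter) are each modest, yet each lies beyond the scatter, so compound 1 stands clear of both.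

Compound 4 `CCc1cc(Nc2nc(N[C@@H](C)c3ccc(F)cn3)nc3cccc(F)c23)n[nH]1` differs from compound 1 in one place: 5-fluoropyridin-2-yl in place of 4-fluorophenyl on a saturated chain carbon bound to a nitrogen on an aromatic ring and a saturated chain carbon. Neither measured step touches this ring: one removes fluoro from the core and the other adds methyl on the saturated chain carbon. Within the data shown here, no measured step therefore bears on the change, and the expectation can rest only on the exchange being a ring of matching size with a single hetero atom added. The expected step in this assay is none beyond the scatter, with the direction open.

Compound 4 is expected to give 55 nM in this assay, within 18 nM to 170 nM. This estimate means a step of a 1.3-fold higher number from compound 1 to compound 4 (0.13 log units; within the scatter).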

Compound 4, half-maximal inhibitory concentration: 29 nM
Beside the measured number, compound 4's estimate is 1.9-fold (0.28 log units) above it; measured number inside the range.
By their numbers in this assay, from the lowest: compounds 4 and 1 (each within the scatter of the next); then compound 3; then compound 2.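

In this assay, 5-fluoropyridin-2-yl in place of 4-fluorophenyl gives (a 1.4-fold lower number from compound 1 to compound 4 (0.15 log units; within the scatter)), so one ring carbon of the side arm can be exchanged for nitrogen, adding a hydrogen-bond acceptor, with no difference beyond the scatter. Within the data shown here, the earlier steps touched only the core and the saturated chain carbon, so this is the first reading on the side-arm ring itself, and it shows that this ring need not be carbon only to keep the number of compound 1. Nothing measured here gives a reason for this result.

As far as these compounds go, whether the same exchange holds on the core of compound 3, which lacks the core fluoro, stays open. So does the outcome with pyrimidin-2-yl as the ring, or with a nitrile or a methoxy group in place of the ring fluoro.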